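Adding a Fluoro Group to Compound 3

This account rests on a few compounds, and the source may have more. Where it says the series, first, only, none or still open, it means among the compounds named here.

The three measured compounds and their values:
Compound 1, `Nc1scc(-c2ccccc2)c1C(=O)c1ccccc1`, gives 49% in a functional assay on CHO cells for agonist activity at adenosine receptor A1 (Homo sapiens), read by fluorescence and ERK phosphorylation, with stated times of 30 min and 1.5 h, tested at 3 uM; a higher number here means a stronger effect of the compound at the concentration tested, a lower number a weaker effect.
Compound 2, `Nc1scc(-c2ccccc2F)c1C(=O)c1ccccc1`, gives 55% in this assay.
Compound 3, `Nc1scc(-c2ccccc2)c1C(=O)c1ccc(Cl)cc1`, gives 51% in this assay.

Among these three numbers compound 3 is second highest, but every gap is small: the step of a number 2 percentage points higher from compound 1 to compound 3 (within the scatter) lies within the usual scatter, and the values of compound 2 and compound 3 also lie within the scatter of each other. In effect the three compounds behave alike.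

Compound 4, `Nc1scc(-c2ccccc2F)c1C(=O)c1ccc(Cl)cc1`, is not yet measured. It differs from compound 3 by fluoro in place of hydrogen on an aromatic carbon. For the measured compounds named here, the one measured step that bears on this change is a number 6 percentage points higher from compound 1 to compound 2 (within the scatter), where the same fluoro group was added to the same ring of compound 1 and no effect beyond the scatter appeared. On that basis the step of a number 4 percentage points higher from compound 3 to compound 4 (within the scatter) is expected to be small as well, with no change beyond the scatter in this assay. Compound 4 is therefore estimated at 55%, with a likely range from 40% to 70%.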

Compound 4, a percentage reported as activity, at one concentration (the size of the read-out at that concentration, not a potency): 70%
Beside the measured number, compound 4's estimate is 15 percentage points below it; the measured number falls inside the stated range.
By their numbers in this assay, from the lowest: compounds 1, 3 and 2 (each within the scatter of the next); then compound 4.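

In this assay, with the chloro group present, fluoro in place of hydrogen on the aromatic carbon ortho to a large group gives a number 19 percentage points higher from compound 3 to compound 4 (beyond the scatter), and with the fluoro group present, chloro in place of hydrogen gives a number 15 percentage points higher from compound 2 to compound 4 (beyond the scatter). Each group thus passes the scatter only with the other in place, yet this does not establish that the two groups reinforce each other: the same change on two cores in this assay, a number 6 percentage points higher (within the scatter) from compound 1 to compound 2 and a number 19 percentage points higher (beyond the scatter) from compound 3 to compound 4, 13 percentage points apart, within the scatter of two such steps. The chloro change reads the same way: the same change on two cores in this assay, a number 2 percentage points higher (within the scatter) from compound 1 to compound 3 and a number 15 percentage points higher (beyond the scatter) from compound 2 to compound 4, 13 percentage points apart, within the scatter of two such steps.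

The compounds shown leave open whether this rise is specific to fluoro or would also appear with a methoxy group or a nitrile at the same place. With one tested concentration, the read-out shows only a stronger or weaker effect at that concentration.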